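Swapping Methyl for Fluoro on Compound 3

The compounds below may be only part of what the source reports. "The series", "measured", "known", "first", "only" and "open" are said of these compounds alone.

Of the compounds shown here, three built on a shared core have been tested in a functional assay on MCF7 cells (Homo sapiens) for inhibition, with a stated time of 96 h; on this read-out lower numbers stand for stronger inhibition and higher numbers for weaker inhibition. There, compound 1 `COc1cc(C(=O)c2cn(-c3ccc(F)cc3)cc2-c2ccco2)cc(OC)c1OC` gives 17 nM, compound 2 `COc1cc(C(=O)c2cn(-c3ccc(F)cc3)cc2-c2nccs2)cc(OC)c1OC` gives 22 nM and compound 3 `COc1cc(C(=O)c2cn(-c3ccc(C)cc3)cc2-c2cccnc2)cc(OC)c1OC` gives 19 nM. Compound 3 lies within the usual scatter of both others, so these three numbers cannot be ranked.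

Compound 4 `COc1cc(C(=O)c2cn(-c3ccc(F)cc3)cc2-c2cccnc2)cc(OC)c1OC` has not yet been measured. It differs from compound 3 by a single change: fluoro in place of methyl on an aromatic carbon, turning 4-methylphenyl into 4-fluorophenyl. Going by the values given here, no measured pair shows this swap directly. Among the compounds with values here, the only measured step, a 1.3-fold higher number from compound 1 to compound 2 (0.11 log units; within the scatter), concerns a different group. It bears on the question only indirectly, since both of its compounds already carry 4-fluorophenyl and their values stay within the scatter of the value for compound 3.

No change beyond the scatter is therefore expected in this assay. The expected step is a 1.1-fold higher number from compound 3 to compound 4 (0.02 log units; within the scatter). Compound 4 is estimated at 20 nM, with an expected range from 9 nM to 45 nM.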

Compound 4, half-maximal inhibitory concentration: 39 nM
The estimate for compound 4 lay 2.0-fold (0.29 log units) below the measured number; the measured number falls inside the stated range.
By their numbers in this assay, from the lowest: compounds 1, 3, 2 and 4 (each within the scatter of the next, the first and the last beyond it).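

In this assay, going by these compounds alone, this position now has its first direct test: fluoro in place of methyl gives a 2.1-fold higher number from compound 3 to compound 4 (0.31 log units; beyond the scatter) as a modest loss with pyridin-3-yl on the shared core, which the earlier compounds, all within the scatter of one another, could not show. With 4-fluorophenyl held fixed, the other aromatic group also matters to a degree: pyridin-3-yl in place of furan-2-yl gives a 2.3-fold higher number from compound 1 to compound 4 (0.36 log units; beyond the scatter) and a modest loss, whereas pyridin-3-yl in place of 1,3-thiazol-2-yl gives a 1.8-fold higher number from compound 2 to compound 4 (0.25 log units; within the scatter) and no readable change. Nothing measured here accounts for these steps.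

4-Methylphenyl appears only with pyridin-3-yl, so whether the swap behaves alike with furan-2-yl or 1,3-thiazol-2-yl stays open. On these data alone, how a methoxy group, a chlorine atom or an amine would read at this place also stays open.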